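Bromo for chloro on the shared core

The source may report more compounds than this note shows. Statements on the series, on what has been measured and on what is new or still open speak of the compounds shown alone.

In a functional assay on MCF7 cells (Homo sapiens) for inhibition (on this read-out lower numbers stand for stronger inhibition and higher numbers for weaker inhibition), compound 1 `Oc1ccc(-c2nc3cc(C(F)(F)F)ccc3s2)cc1` gives 13800 nM as its reading. Compound 2 `Oc1ccc(-c2nc3ccc(Cl)cc3s2)cc1` gives 26500 nM in this assay as well, a value within the usual scatter of that of compound 1, so the two cannot be told apart. Compound 3 `Oc1ccc(-c2nc3ccc(Br)cc3s2)cc1` carries bromo in place of chloro on an aromatic carbon and has no reading yet. Among the compounds with values here, no measured step between compounds speaks to this swap, so nothing beyond the scatter is expected. The expected step of a 1.2-fold lower number from compound 2 to compound 3 (0.06 log units; within the scatter) is therefore small. Compound 3 is estimated at 23000 nM in this assay with a range from 11000 nM to 48000 nM for repeated measurements.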

Compound 3, half-maximal inhibitory concentration: 4160 nM
Estimate against measurement, compound 3: 5.5-fold (0.74 log units) above; the measured number lies below the stated range.
By their numbers in this assay, from the lowest: compound 3; then compounds 1 and 2 (each within the scatter of the next).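

At this place on the shared core, the identity of the halogen matters: in this assay bromo in place of chloro gives a 6.4-fold lower number from compound 2 to compound 3 (0.80 log units; beyond the scatter), although the exchange swaps one heavy atom for another and adds no ring, hydrogen-bond donor, hydrogen-bond acceptor or net charge. Nothing in the available data accounts for this step. The compounds shown leave open whether the stronger inhibition is particular to bromo, or whether fluoro, iodo or an amine on the same aromatic carbon would give a similar reading.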